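The source may report more compounds than this note shows. Statements on the series, on what has been measured and on what is new or still open speak of the compounds shown alone.

Measured compounds:
compound 1 `COc1ccc(F)cc1N1C(=O)CSC1c1cccc(C(=O)NCCCCc2ccccc2)c1` gives 2300 mL.min-1.g-1
compound 2 `Cc1ccnc(N2C(=O)CSC2c2cccc(C(=O)NCCCCn3cccn3)c2)c1` gives 1020 mL.min-1.g-1

Among the compounds with values here, both numbers come from an ADME assay on microsomes from liver (Rattus norvegicus) for metabolic stability, read by LC-MS, using NADPH, with a stated time of 10 min, tested at 0.1 uM (a higher number here means faster removal of the compound, a lower number slower removal), and are the only measurements so far. Compound 1 holds the higher of the two numbers, and its gap to compound 2 lies beyond the usual scatter of repeated measurements. These two compounds differ in more than one place, so their gap cannot be tied to any single group.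

Compound 3 `O=C(NCCCCc1ccccc1)c1cccc(C2SCC(=O)N2c2cccc(F)c2)c1` has not yet been measured. Its difference from compound 1 is hydrogen in place of methoxy on an aromatic carbon, ortho to a large group and para to a fluoro group, so that 5-fluoro-2-methoxyphenyl becomes 3-fluorophenyl. Within the data shown here, no measured pair shows this change on its own, which leaves the expectation rough. A small downward step in this assay is expected, most likely not beyond the scatter. The expected step is a 1.3-fold lower number from compound 1 to compound 3 (0.11 log units; within the scatter) in this estimate. For compound 3 the estimated value is 1800 mL.min-1.g-1, with an expected range from 800 mL.min-1.g-1 to 3500 mL.min-1.g-1.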

Compound 3, intrinsic clearance in microsomes: 3240 mL.min-1.g-1
Estimate against measurement, compound 3: 1.8-fold (0.26 log units) below; low and high end bracket the measured number.
By their numbers in this assay, from the lowest: compound 2; then compounds 1 and 3 (each within the scatter of the next).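

In this assay, within the data shown here, compounds 1 and 3 form the first pair that differs in one place, and hydrogen in place of methoxy on this aromatic carbon, ortho to a large group and para to a fluoro group, gives a 1.4-fold higher number from compound 1 to compound 3 (0.15 log units; within the scatter). On this evidence, the methoxy group can be exchanged for hydrogen at this position without a step that stands out from the usual spread of repeated measurements, so this single exchange does not separate the two compounds in this read-out. Nothing in hand explains this result.

Hydrogen and methoxy are the only two groups compared at this position, so it remains open whether a hydroxyl group, a chlorine atom, an amine or a carboxylic acid on the same carbon would give a step beyond the scatter. It is also open whether the same exchange would give a similar step with a different chain on the amide, because the pair shown carries only the one chain ending in a phenyl ring.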